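The compounds below may be only part of what the source reports. "The series", "measured", "known", "first", "only" and "open" are said of these compounds alone.

Measured in an ADME assay on microsomes from liver (Mus musculus) for metabolic stability, using NADPH, with a stated time of 10 min; on this read-out lower numbers stand for a less stable compound and higher numbers for a more stable compound:
- compound 1 `CN(C)C1CCN(c2cccc3c2C[C@H](CN(C)[C@H]2CCCc4cccnc42)NC3)CC1`: 70.2%
- compound 2 `CN(C[C@H]1Cc2c(cccc2N2C[C@H]3CCN(C)[C@H]3C2)CN1)[C@H]1CCCc2cccnc21`: "not determined" (no result reported)
- compound 3 `CN(C[C@H]1Cc2c(cccc2N[C@H]2CC[C@H](N)CC2)CN1)[C@H]1CCCc2cccnc21`: 100%

Compound 3 holds the highest number here, while compound 2 has no number to compare. Compound 4 `CN1C[C@@H]2CN(c3cccc4c3C[C@H](CN(C)[C@H]3CCCc5cccnc53)NC4)C[C@@H]2C1` is still unmeasured, and its change from compound 3 is this: a group of 9 heavy atoms (7 carbon, 2 nitrogen; 2 five-membered non-aromatic rings with 1 hetero atom each) in place of a group of 8 heavy atoms (6 carbon, 2 nitrogen; one six-membered non-aromatic ring of carbon only), on an aromatic carbon. Among the measured compounds shown here, one measured step bears on it: a number 29.8 percentage points higher from compound 1 to compound 3 (beyond the scatter). In that step the (4-aminocyclohexyl)amino group entered, whereas here it leaves, so a fall of similar size is expected. For the measured compounds named here, the entering group differs from the one in compound 1, which keeps this expectation loose. The expected change is a number 28 percentage points lower from compound 3 to compound 4 (beyond the scatter). For compound 4 the estimated value is 72%, with an expected range from 45% to 95%.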

Compound 4, percent of the compound remaining: 32.9%
The estimate for compound 4 lay 39.1 percentage points above the measured number; the measured number lies below the stated range.
By their numbers in this assay, from the lowest: compound 4; then compound 1; then compound 3.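

Changing the group on this aromatic carbon can move the number a long way in this assay: a number 67.1 percentage points lower from compound 3 to compound 4 (beyond the scatter) and a number 37.3 percentage points lower from compound 1 to compound 4 (beyond the scatter). The second step shows that two groups of 9 heavy atoms, one with a six-membered ring and one with two five-membered rings, need not behave alike. Nothing measured here explains either fall. Compound 3 and compound 4 differ in ring type and in hydrogen-bond donors together, so the compounds shown cannot separate the two. A piperazine at this position would add another ring to compare, and a (4-aminopiperidin-1-yl) group would test a ring amine carrying a free amine.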